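Swapping a Ring for a Difluoroethyl Group

The compounds below may be only part of what the source reports. "The series", "measured", "known", "first", "only" and "open" are said of these compounds alone.

Among the compounds with values here, compound 2 `CS(=O)(=O)Nc1ccc(CNC(=O)c2ccc(N3CCCCC3)cc2)c(Cl)c1` is one of two compounds measured in an assay on HeLa cells for agonist activity at Bile acid receptor (Homo sapiens), read by a luciferase reporter, with a stated time of 24 h (on this read-out lower numbers stand for an effect already at smaller amounts and higher numbers for an effect only at larger amounts of compound), where compound 2 gives 410 nM. Compound 1 `CS(=O)(=O)Nc1ccc(CNC(=O)c2ccc(C34CC(C3)C4)cc2)c(Cl)c1` gives 560 nM in this assay. Compound 2 thus holds the lowest of the two numbers, yet the step of a 1.4-fold lower number from compound 1 to compound 2 (0.14 log units; within the scatter) shows that the two values lie within the scatter of each other. Compound 3 `CC(F)(F)c1ccc(C(=O)NCc2ccc(NS(C)(=O)=O)cc2Cl)cc1` has not yet been measured; it differs from compound 2 by 1,1-difluoroethyl in place of piperidin-1-yl on an aromatic carbon. Within the data shown here, the only measured step concerns the same aromatic carbon: there one group replaced another and the numbers stayed within the scatter. Among the measured compounds shown here, that single step is the only guide, and it suggests no large change. Compound 3 is therefore expected to give a number close to that of compound 2. The step of a 1.2-fold higher number from compound 2 to compound 3 (0.09 log units; within the scatter) is estimated to stay within the scatter. The estimate for compound 3 is 500 nM, with a range from 180 nM to 1400 nM.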

Compound 3, half-maximal effective concentration: 1200 nM
For compound 3 the middle estimate is 2.4-fold (0.38 log units) below the measured one, within the range that was stated.
By their numbers in this assay, from the lowest: compounds 2 and 1 (each within the scatter of the next); then compound 3.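

This position, para to a large group, does respond to the change in this assay: the move to 1,1-difluoroethyl gives a modest shift beyond the scatter (a 2.9-fold higher number from compound 2 to compound 3 (0.47 log units; beyond the scatter)), and the comparison with the other ring-bearing compound agrees (a 2.1-fold higher number from compound 1 to compound 3 (0.33 log units; beyond the scatter)). The earlier step between the two ring-bearing groups stayed within the scatter (a 1.4-fold lower number from compound 1 to compound 2 (0.14 log units; within the scatter)), so here those two groups stand together and the open group without a ring stands apart from both. (Nothing measured here gives a reason for this gap)

Piperidin-1-yl and 1,1-difluoroethyl differ both in the ring and in the fluorine atoms, so the compounds shown leave open which of these differences matters. An isopropyl group or a morpholine ring on the same aromatic carbon would bear on that question.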